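Fluoro for trifluoromethyl on an arylpiperazine sulfonamide

The source may report more compounds than this note shows. Statements on the series, on what has been measured and on what is new or still open speak of the compounds shown alone.

Compound 1 `COc1ccc(S(=O)(=O)NCCCN2CCN(c3ccc(C(F)(F)F)cc3)CC2)cc1` gives 384 nM in an assay on CHO cells for displacement of a labelled ligand from 5-hydroxytryptamine receptor 7 (Homo sapiens); a lower number here means a stronger inhibitor, a higher number a weaker inhibitor. Compound 2 `O=S(=O)(NCCCN1CCN(c2ccc(C(F)(F)F)cc2)CC1)c1ccc2ccccc2c1` gives 567 nM in this assay.

Among the compounds with values here, of the two numbers, compound 2 has the higher one, yet its only neighbour is compound 1, and the step of a 1.5-fold higher number from compound 1 to compound 2 (0.17 log units; within the scatter) stays within the scatter, so the two compounds cannot be ordered. That step changes the aryl on the sulfonyl sulfur, not the aryl on the piperazine.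

Compound 3 `O=S(=O)(NCCCN1CCN(c2ccc(F)cc2)CC1)c1ccc2ccccc2c1` is not yet measured. It differs from compound 2 by fluoro in place of trifluoromethyl on an aromatic carbon. Within the data shown here, none of the measured steps touches this aromatic ring, so nothing here tells how this assay responds to the exchange. Without a bearing step, the step of a 1.2-fold higher number from compound 2 to compound 3 (0.09 log units; within the scatter) is expected to be small, with no direction beyond the scatter claimed. Compound 3 is therefore estimated at 700 nM in this assay, within a range from 250 nM to 2000 nM, the width of that range reflecting the absence of any comparable measured change.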

Compound 3, half-maximal inhibitory concentration: 53 nM
Estimate against measurement, compound 3: 13-fold (1.12 log units) above; measured number outside the range, below it.
By their numbers in this assay, from the lowest: compound 3; then compounds 1 and 2 (each within the scatter of the next).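

Within the data shown here, the aryl on the piperazine, which no earlier step had touched, proves to be a place to which this assay responds strongly: the exchange brings an 11-fold lower number from compound 2 to compound 3 (1.03 log units; beyond the scatter), whereas the only earlier step, on the sulfonyl sulfur, brought a 1.5-fold higher number from compound 1 to compound 2 (0.17 log units; within the scatter). So, among the compounds shown, the one clear change in the number comes with going from 4-(trifluoromethyl)phenyl to 4-fluorophenyl, where a group of 4 heavy atoms gives way to a single fluorine on an aromatic carbon, with the naphthalen-2-yl sulfonamide and the rest of the core unchanged. Nothing measured here says what lies behind a step of this size.

As far as these compounds go, the exchange has been read only once, with naphthalen-2-yl on the sulfonyl sulfur, so it remains open whether it would carry the same weight with the 4-methoxyphenyl of compound 1. From the compounds shown here alone, it is also open how the number would respond to chloro, methyl or methoxy in that same place on the ring, or to a plain hydrogen there, which would show whether fluoro itself matters or merely the loss of trifluoromethyl.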